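Exchanging the Aryl Group: Two Limits and an Open Question

This account rests on a few compounds, and the source may have more. Where it says the series, first, only, none or still open, it means among the compounds named here.

Values in an ADME assay on PANC-1 cells (Homo sapiens) for cytotoxicity, read by MTT assay; a lower number here means that less compound is tolerated, a higher number that more compound is tolerated:
Compound 1 `Cc1nc(-c2cccnc2)sc1-c1nnc(-c2ccccc2Cl)o1`: > 100 ug/mL
Compound 2 `Cc1nc(-c2cccnc2)sc1-c1nnc(-c2ccc(O)cc2)o1`: > 100 ug/mL

Compound 1 gives a reading that is a limit of the assay rather than a number. Compound 2 likewise gives only a limit. The step that the two limits leave unreadable from compound 1 to compound 2 is therefore not readable, and compound 2 stands at the ceiling of this assay, where the limit of > 100 ug/mL in this assay, at which 2 of the 2 values shown sit, places both values on hand. Compound 3 `Cc1nc(-c2cccnc2)sc1-c1nnc(-c2cccnc2)o1` has not been measured. It differs from compound 2 by pyridin-3-yl in place of 4-hydroxyphenyl on an aromatic carbon. Among the compounds with values here, the single measured step concerns a different exchange and yields no size or direction, so nothing in the data points to a change. Compound 3 is therefore expected to move no further than the scatter, its step from compound 2 being a step that the limit leaves unreadable from compound 2 to compound 3. In this assay compound 3 is estimated at 150 ug/mL, with a range from 60 ug/mL to 400 ug/mL, and most probably the assay will again report only a limit.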

Compound 3, half-maximal cytotoxic concentration: > 100 ug/mL
Compound 3: a limit, no number; the forecaster's own chance of this, stated with the estimate: 80%; the middle value lies beyond the limit too.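

Compound 3 also gives only a limit, so no step among compound 1, compound 2 and compound 3 can be read: the limit of > 100 ug/mL in this assay, at which 3 of the 3 values shown sit.

The compounds shown leave open whether 2-chlorophenyl, 4-hydroxyphenyl and pyridin-3-yl differ at all in this assay.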